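The compounds below may be only part of what the source reports. "The series", "measured", "known", "first", "only" and "open" are said of these compounds alone.

Compound 1 `CN1C(=O)C2(C(C#N)=C(N)Oc3cc4oc(-c5ccccc5)cc(=O)c4c(O)c32)c2ccccc21` gives > 50000 nM in a functional assay on PC-3 cells (Homo sapiens) for antiproliferative activity, read by MTT assay, with a stated time of 48 h (a higher number here means a weaker inhibitor, a lower number a stronger inhibitor), which is a limit of the assay and not a number.
Compound 2 `CN1C(=O)C2(C(C#N)=C(N)Oc3cc4oc(-c5ccccc5)cc(=O)c4c(O)c32)c2cc(Cl)ccc21` gives 21400 nM in this assay.
Compound 3 `N#CC1=C(N)Oc2cc3oc(-c4ccccc4)cc(=O)c3c(O)c2C12C(=O)Nc1ccccc12` gives > 50000 nM in this assay, again only a limit.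

Compound 2 differs from compound 1 by chloro in place of hydrogen on an aromatic carbon, and this change brings an at least 2.3-fold lower number from compound 1 to compound 2 (0.36 log units; beyond the scatter). The two cores differ by hydrogen in place of methyl on an amide-type nitrogen in a ring; the step that the two limits leave unreadable from compound 1 to compound 3 cannot be sized because the limit of > 50000 nM in this assay, at which 2 of the 3 values shown sit, holds both readings.

Compound 4 `N#CC1=C(N)Oc2cc3oc(-c4ccccc4)cc(=O)c3c(O)c2C12C(=O)Nc1c(Cl)cccc12` has not been measured yet. It differs from compound 3 by chloro in place of hydrogen on an aromatic carbon. Going by the values given here, this is the same kind of change as the one from compound 1 to compound 2, but not the same: in compound 4 the chloro sits ortho to a fused ring and meta to a fused ring, whereas in compound 2 it sits meta to a fused ring and para to a fused ring.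

In this assay compound 4 is expected to show an at least 1.4-fold lower number from compound 3 to compound 4 (0.15 log units; that floor lies within the scatter), an expectation that rests on the step of an at least 2.3-fold lower number from compound 1 to compound 2 (0.36 log units; beyond the scatter) seen with compound 2, though the place of the chloro is not the same. The estimate for compound 4 is 35000 nM, with a range expected from 12000 nM to 100000 nM.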

Compound 4, half-maximal inhibitory concentration: > 50000 nM
Compound 4 ended at the assay's limit; the forecaster's own chance of this, stated with the estimate: 45%; at least 1.4-fold (0.15 log units) between middle value and limit.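

Compound 4 gives > 50000 nM in this assay, which is a limit of the assay and not a number. Compound 3 also stands at a limit, so the change from compound 3 to compound 4 cannot be read as a step: the limit of > 50000 nM in this assay, at which 3 of the 4 values shown sit.

The compounds shown leave open whether chloro on the core of compound 3 changes the number at all, and whether the place of the chloro matters.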